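A few compounds are considered here, and "the series" means these few. Any claim that something is new, unique, unknown or untested is made for them only; others in the source may bear on it.

Compound 1 `CCNC(=O)Nc1ccc(-c2nc(N3CC4CCC(C3)O4)c3cnn(C4CCC5(CC4)OCCO5)c3n2)cc1`: 0.167 h
Compound 2 `CNC(=O)Nc1ccc(-c2nc(N3CC4CCC(C3)O4)c3cnn([C@H]4CC[C@@H](O)CC4)c3n2)cc1`: > 0.5 h
Compound 3 `CNC(=O)Nc1ccc(-c2nc(N3CC4CCC(C3)O4)c3cnn(C4CCC5(CC4)OCCCO5)c3n2)cc1`: > 0.5 h

Within the data shown here, in an in vitro ADME assay on microsomes (Homo sapiens) for metabolic stability (a higher number here means that the compound lasts longer, a lower number that the compound disappears faster), compound 1 gives 0.167 h, the only true number among the three. Compound 2 gives > 0.5 h, which is a limit and not a number. Compound 3 gives > 0.5 h, which is also a limit. Going by these compounds, compound 3 therefore stands at the limit of > 0.5 h in this assay, at which 2 of the 3 values shown sit, and its exact half-life is unknown.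

Compound 4 `CNC(=O)Nc1ccc(-c2nc(N3CC4CCC(C3)O4)c3cnn([C@H]4CC[C@H](O)CC4)c3n2)cc1` has not yet been measured. The change from compound 3 is a group of 7 heavy atoms (6 carbon, 1 oxygen; one six-membered non-aromatic ring of carbon only) in place of a group of 11 heavy atoms (9 carbon, 2 oxygen; one six-membered non-aromatic ring of carbon only, one six-membered non-aromatic ring with 2 hetero atoms), on an aromatic nitrogen: 4-hydroxycyclohexyl enters on an aromatic nitrogen, in place of the larger group of 11 heavy atoms.

Among the measured compounds shown here, one measured step bears on this: a step that the two limits leave unreadable from compound 2 to compound 3. It links the same two group sizes, but both of its ends are limits, so it offers no size to carry over. No step beyond the usual scatter is therefore expected in this assay, in either direction. The estimated change is a number no higher from compound 3 to compound 4 (the limit leaves the size open). For compound 4 the estimate is 0.5 h, with an expected range from 0.25 h to 1 h.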

Compound 4, half-life: > 0.5 h
Compound 4: no number, only a limit (the forecaster's own chance of this, stated with the estimate: 70%); the middle value lies on the limit itself.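

Compound 2, compound 3 and compound 4 each give a limit and not a number in this assay, so no step among them can be read: the limit of > 0.5 h in this assay, at which 3 of the 4 values shown sit.

The compounds shown leave open how long each of these three actually lasts, and whether the drawn configuration of the 4-hydroxycyclohexyl group makes any difference to that.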